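Fluoro for chloro on the aryl ring of an oxadiazole amide

This account rests on a few compounds, and the source may have more. Where it says the series, first, only, none or still open, it means among the compounds named here.

Compound 1 `O=C(c1ccc(Cl)cc1)N1CC(c2nc(-c3cccc(F)c3)no2)C1`: > 10000 nM
Compound 2 `O=C(c1ccc(F)cc1)N1CC(c2nc(-c3cccc(Cl)c3)no2)C1`: 4000 nM

Of the compounds shown here, two sharing one core have been tested in an assay on HEK293 cells for negative allosteric modulation of metabotropic glutamate receptor 5 (Homo sapiens), read by FLIPR; a higher number here means a weaker inhibitor, a lower number a stronger inhibitor. Compound 1 gives only a limit, > 10000 nM, which marks the edge of this assay and is not a number. Compound 2 gives 4000 nM, the only numerical result so far, so it stands as the single fixed point among the values shown. The other value, that of compound 1, is a limit (the limit of > 10000 nM in this assay, at which 1 of the 2 values shown sits).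

Compound 3 `O=C(c1ccc(F)cc1)N1CC(c2nc(-c3cccc(F)c3)no2)C1` is the next compound to be measured in this assay. It differs from compound 2 in one place: fluoro in place of chloro on an aromatic carbon, so a 3-chlorophenyl becomes a 3-fluorophenyl on the ring attached to the oxadiazole. Among the measured compounds shown here, no measured pair shows this exchange on this core, so its effect has to be estimated. The writer expects a modest loss of potency, with the step from compound 2 to compound 3 being a 2.0-fold higher number from compound 2 to compound 3 (0.30 log units; within the scatter), a shift somewhat beyond the usual scatter but not large. On that basis compound 3 is estimated at 8000 nM in this assay, with a range from 3000 nM to 20000 nM, and a real chance that only a limit is reported.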

Compound 3, half-maximal inhibitory concentration: > 10000 nM
Compound 3: no number, only a limit (the forecaster's own chance of this, stated with the estimate: 40%); middle value at least 1.2-fold (0.09 log units) away from the limit.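

In this assay, among the compounds shown here, the exchange of 3-chlorophenyl for 3-fluorophenyl gives an at least 2.5-fold higher number from compound 2 to compound 3 (0.39 log units; beyond the scatter), the first readable step on the shared core. Going by these compounds, it shows that this position is sensitive to which halogen it carries: with chloro the result is a number, and with fluoro it is only a limit, so the printed step is a lower bound and the true size of the loss stays unknown. Compound 1 and compound 3 both end at a limit, so the step between them cannot be read and the effect of the halogen on the other aryl ring remains unresolved: the limit of > 10000 nM in this assay, at which 2 of the 3 values shown sit.

What the compounds shown leave open is whether chloro is the better of a wider set at this position, since bromo, methyl, methoxy or trifluoromethyl in its place could move the number in either direction. Also open, on these data alone, is whether chloro on both aryl rings would give a lower number than compound 2 shows, and whether an amine or a nitrile on either ring would be tolerated at all.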